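A Thioether Variant of a Long-Lived Ether Series

The compounds below may be only part of what the source reports. "The series", "measured", "known", "first", "only" and "open" are said of these compounds alone.

Compound 1 `Cc1cc(CCOc2ccc(-c3c(C)nc(C)c([C@H](OC(C)(C)C)C(=O)O)c3N3CCC(C)(C)CC3)cc2)ccc1F`: > 2 h
Compound 2 `Cc1nc(C)c([C@H](OC(C)(C)C)C(=O)O)c(N2CCC(C)(C)CC2)c1-c1ccc(OCCc2ccc(F)c(F)c2)cc1`: > 2 h
Compound 3 `Cc1nc(C)c([C@H](OC(C)(C)C)C(=O)O)c(N2CCC(C)(C)CC2)c1-c1ccc(OCCCc2ccc(F)cc2)cc1`: > 2 h

In an ADME assay on microsomes from liver (Homo sapiens) for metabolic stability, read by LC-MS, tested at 0.5 uM (a lower number here means that the compound disappears faster, a higher number that the compound lasts longer), compound 1 gives > 2 h, which is a limit of the assay rather than a number. The value of compound 2 is a limit as well. The value of compound 3 is likewise a limit. Compound 4 `Cc1nc(C)c([C@H](OC(C)(C)C)C(=O)O)c(N2CCC(C)(C)CC2)c1-c1ccc(SCCc2ccc(F)cc2)cc1` keeps the shared core of compound 1 and differs in that ((2-(4-fluorophenyl)ethyl)sulfanyl in place of 2-(4-fluoro-3-methylphenyl)ethoxy on an aromatic carbon). The measured steps offer little guidance: a step that the two limits leave unreadable from compound 1 to compound 2, a step that the two limits leave unreadable from compound 1 to compound 3 and a step that the two limits leave unreadable from compound 2 to compound 3 are all unreadable because of the limit of > 2 h in this assay, at which 3 of the 3 values shown sit. Among the measured compounds shown here, no measured step touches the ether oxygen itself, so the change to sulfur stands without precedent here. Compound 4 is expected to give 2.5 h in this assay, within a range of 0.9 h to 6 h, an expected step that the limit leaves unreadable from compound 1 to compound 4.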

Compound 4, half-life: > 2 h
Compound 4: a limit, no number; the forecaster's own chance of this, stated with the estimate: 60%; the middle value is on the limit's open side.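

In this assay compound 4 gives > 2 h as a limit and not a number. Its steps from compound 1, compound 2 and compound 3 cannot be read because of this shared ceiling: the limit of > 2 h in this assay, at which 4 of the 4 values shown sit. From the compounds shown here alone, how long each of these four compounds actually lasts stays open.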